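This account rests on a few compounds, and the source may have more. Where it says the series, first, only, none or still open, it means among the compounds named here.

Measured in a functional assay on HCT-116 cells (Homo sapiens) for cytotoxicity, read by MTT assay, with a stated time of 72 h; on this read-out lower numbers stand for stronger inhibition and higher numbers for weaker inhibition:
- Compound 1 `Nc1cccc(Nc2c(C(=O)NCc3ccc(F)cc3)nc(Br)c3cccnc23)c1`: > 10000 nM (a limit)
- Compound 2 `NCCCNc1c(C(=O)NCc2ccc(F)cc2)nc(Br)c2cccnc12`: > 20000 nM (a limit)
- Compound 3 `N[C@H]1CC[C@H](Nc2c(C(=O)NCc3ccc(F)cc3)nc(Br)c3cccnc23)CC1`: 7000 nM

For the measured compounds named here, compound 3 stands at 7000 nM, the only true number in the set. The other two results are limits. Compound 4 `CNc1c(C(=O)NCc2ccc(F)cc2)nc(Br)c2cccnc12` has methyl in place of 4-aminocyclohexyl on a nitrogen on an aromatic ring.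

Two measured steps at that same nitrogen bear on this change. One is an at least 2.8-fold lower number from compound 2 to compound 3 (0.45 log units; beyond the scatter). The other is an at least 1.4-fold lower number from compound 1 to compound 3 (0.15 log units; that floor lies within the scatter). So neither replacement of the 4-aminocyclohexyl group gave a better result in this assay, although only the first step is clearly beyond the scatter. Going by the values given here, none of the measured compounds carries methyl here, which makes this a cautious extrapolation.

The expected change is a 2.1-fold higher number from compound 3 to compound 4 (0.33 log units; beyond the scatter), towards weaker inhibition. The assay may well report only a limit. Compound 4 is estimated at 15000 nM, with an expected range of 6000 nM to 40000 nM.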

Compound 4, half-maximal inhibitory concentration: > 20000 nM
Compound 4 was reported as a limit (the forecaster's own chance of this, stated with the estimate: 50%); at least 1.3-fold (0.12 log units) between middle value and limit.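

In this assay, putting methyl in place of 4-aminocyclohexyl on this nitrogen gives an at least 2.8-fold higher number from compound 3 to compound 4 (0.45 log units; beyond the scatter), so cutting the group down to methyl does not keep the activity of compound 3. As far as these compounds go, compound 4 gives > 20000 nM, which is a limit and not a number, so the printed step is only a floor and its full size stays unknown. The steps joining compound 4 to compound 1 and to compound 2 cannot be read, and among the four groups shown on this nitrogen only the 4-aminocyclohexyl group gives a true number.

Compound 3 differs from compound 4 in both a ring and an amine, so the compounds shown do not tell which of the two matters. A plain cyclohexyl group without the amine, or a 4-hydroxycyclohexyl group, would help to separate them.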